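From compound 1 to compound 4: one added methyl

This account rests on a few compounds, and the source may have more. Where it says the series, first, only, none or still open, it means among the compounds named here.

Values in a functional assay on HL-60 cells (Homo sapiens) for antiproliferative activity, with a stated time of 72 h (a lower number here means a stronger inhibitor of growth, a higher number a weaker inhibitor of growth), are as follows.
- Compound 1 `C=C(CC)C(=O)c1ccc(OCC(=O)O)cc1Br` gives > 60000 nM as a limit, not a number
- Compound 2 `C=C(CC)C(=O)c1ccc(OCC(=O)O)cc1Cl` gives > 60000 nM as a limit, not a number
- Compound 3 `C=C(C)C(=O)c1ccc(OC(C)C(=O)OC)c(C)c1C` gives 6000 nM as a measured number

Compound 1 therefore stands at the limit of > 60000 nM in this assay, at which 2 of the 3 values shown sit, and its true value cannot be read. Compound 4 `C=C(CC)C(=O)c1ccc(OC(C)C(=O)O)cc1Br` differs from compound 1 by methyl in place of hydrogen on a saturated chain carbon bound to a carbonyl carbon and an oxygen on an aromatic ring so that carboxymethoxy becomes 1-carboxyethoxy.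

Going by the values given here, no measured step shows this change directly. Among the compounds with values here, the only step available is a step that the two limits leave unreadable from compound 1 to compound 2 and it concerns another position and has no readable size. Compound 3 has a measured value, but it differs from compound 1 in several places, so it gives no size for this change either. Within the data shown here, with no step to carry over, the expectation is that compound 4 stays near the limit of compound 1, with no clear move in either direction.

The expected step is a number no higher from compound 1 to compound 4 (the limit leaves the size open) and it is only a rough estimate. Compound 4 is expected at 60000 nM in this assay with an estimated range from 20000 nM to 100000 nM and will most likely be reported only as a limit.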

Compound 4, concentration for 50% growth inhibition: > 60000 nM
Compound 4 gave a limit, no number; the forecaster's own chance of this, stated with the estimate: 75%; the middle value lies on the limit itself.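

In this assay, compound 1 and compound 4 are each reported only as a limit, not a number, so the step between them cannot be read: the limit of > 60000 nM in this assay, at which 3 of the 4 values shown sit. The compounds shown leave open whether changing carboxymethoxy to 1-carboxyethoxy alters growth inhibition at all, in either direction.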